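The source may report more compounds than this note shows. Statements on the series, on what has been measured and on what is new or still open speak of the compounds shown alone.

Compound 1 `CCCCNC(=O)c1c(O)c2cccnc2n(-c2ccccc2)c1=O`: 12.8%
Compound 2 `CN(C)CCNC(=O)c1c(O)c2cccnc2n(-c2ccccc2)c1=O`: 22.6%
Compound 3 `Cc1ccc(NC(=O)c2c(O)c3cccnc3n(-c3ccccc3)c2=O)cc1`: -3.5%

In a functional assay on the whole organism for inhibition, with Rattus norvegicus as the target, read by paw edema, at a dose of 100 mg/kg by the oral route (a higher number here means more inhibition at the dose given (going by the name of the read-out), a lower number less inhibition), compound 1 gives 12.8%, the second highest of the three numbers: compound 2 lies a number 9.8 percentage points higher from compound 1 to compound 2 (within the scatter), and compound 3 lies a number 16.3 percentage points lower from compound 1 to compound 3 (beyond the scatter). Compound 4 `O=C(Nc1cnccn1)c1c(O)c2cccnc2n(-c2ccccc2)c1=O` is not yet measured. It differs from compound 1 by pyrazin-2-yl in place of butyl on an amide-type nitrogen. For the measured compounds named here, the step that bears on this is the one to an aromatic group on the same nitrogen, which came out a number 16.3 percentage points lower from compound 1 to compound 3 (beyond the scatter) and a number 26.1 percentage points lower from compound 2 to compound 3 (beyond the scatter). On that basis a drop beyond the scatter is expected, with the step estimated as a number 12.8 percentage points lower from compound 1 to compound 4 (beyond the scatter). Compound 4 is therefore expected to give about 0%, in a range from -15% to 15%.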

Compound 4, a percentage reported as inhibition, in the whole organism at one dose (the size of the read-out at that dose, not a potency): 29.6%
Beside the measured number, compound 4's estimate is 29.6 percentage points below it; the whole stated range lies below it.
By their numbers in this assay, from the lowest: compound 3; then compounds 1, 2 and 4 (each within the scatter of the next, the first and the last beyond it).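

In this assay, an aromatic group on this amide-type nitrogen does not by itself bring the number down: pyrazin-2-yl in place of butyl gives a number 16.8 percentage points higher from compound 1 to compound 4 (beyond the scatter) here, and in place of 4-methylphenyl it gives a number 33.1 percentage points higher from compound 3 to compound 4 (beyond the scatter) as well. Against the 2-(dimethylamino)ethyl amide, the change gives a number 7 percentage points higher from compound 2 to compound 4 (within the scatter) and so does not separate the two groups. Nothing available explains the gap between the two aromatic groups. Still open, as far as these compounds go, is whether phenyl or pyridin-2-yl on this nitrogen would stand with compound 3 or with compound 4.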